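Two Weak Inhibitors and a Changed Aromatic Group

The source may report more compounds than this note shows. Statements on the series, on what has been measured and on what is new or still open speak of the compounds shown alone.

Measured so far in a functional assay on PC-3 cells (Homo sapiens) for inhibition, read by MTT assay, with a stated time of 48 h; on this read-out lower numbers stand for stronger inhibition and higher numbers for weaker inhibition
- Compound 1 `Cc1c(NC(=O)NCCN2C(=O)S/C(=C\c3ccc([N+](=O)[O-])cc3)C2=O)c(=O)n(-c2ccccc2)n1C` gives 69300 nM
- Compound 2 `Cc1c(NC(=O)CN2C(=O)S/C(=C\c3ccc([N+](=O)[O-])cc3)C2=O)c(=O)n(-c2ccccc2)n1C` gives > 100000 nM (a limit)

Compound 2 stands only at the limit > 100000 nM in this assay and has no exact number. Compound 3 `Cc1cc(C)c(/C=C2\SC(=O)N(CC(=O)Nc3c(C)n(C)n(-c4ccccc4)c3=O)C2=O)c(C)c1` carries 2,4,6-trimethylphenyl in place of 4-nitrophenyl on a double-bonded chain carbon bound to a double-bonded ring carbon. Within the data shown here, no measured step shows what this swap does. Among the measured compounds shown here, a small gain in inhibition is expected in this assay, possibly none beyond the scatter, with compound 1 at 69300 nM as the only firm number nearby. The estimated step of an at least 1.2-fold lower number from compound 2 to compound 3 (0.09 log units; that floor lies within the scatter) rests on that expectation. Compound 3 is expected at 80000 nM with 30000 nM to 150000 nM as the estimated range.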

Compound 3, half-maximal inhibitory concentration: 81600 nM
For compound 3 the middle estimate is 1.0-fold (0.01 log units) below the measured one; the range from low to high includes it.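

In this assay, 2,4,6-trimethylphenyl in place of 4-nitrophenyl gives an at least 1.2-fold lower number from compound 2 to compound 3 (0.08 log units; that floor lies within the scatter). The position therefore accepts an all-carbon aromatic group without a nitro group, and compound 3 gives 81600 nM, an exact number for this series with the shorter chain. The true size of the step cannot be read, because compound 2 is known only as a limit: the limit of > 100000 nM in this assay, at which 1 of the 3 values shown sits.

Still open, going by these compounds, is whether an amine or a carboxylic acid on the aromatic ring at this position would give a clearly lower number.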